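The compounds below may be only part of what the source reports. "The series", "measured", "known", "first", "only" and "open" are said of these compounds alone.

The measured compounds:

compound 1 `CCOC(=O)CC(=O)N1CCSC1COc1ccccc1OC`: 11 mg/kg
compound 2 `O=C(O)[C@@H]1CSC(CCc2ccccc2O)N1`: 45 mg/kg
compound 3 `CSCC(=O)N1CCSC1COc1ccccc1O`: 28 mg/kg

In a functional assay on the whole organism (trachea) for inhibition, with Cavia porcellus as the target (a higher number here means that more compound is needed for the effect, a lower number that less compound is needed), compound 1 has the lowest of the three numbers. Compound 3 lies beyond the scatter above it, and compound 2 lies further above still. No two of these compounds differ in only one place, so no single-change step can be read from them.

Compound 4 `COc1ccccc1OCC1SCCN1C(=O)C[S+](C)[O-]` is the compound not yet measured. It differs from compound 1 as follows: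

a group of 3 heavy atoms (1 carbon, 1 oxygen, 1 sulfur; no ring) in place of a group of 5 heavy atoms (3 carbon, 2 oxygen; no ring), on a saturated chain carbon bound to a carbonyl carbon

Within the data shown here, with no comparable step among the measured compounds, the change in this assay is expected to be modest, at most a small rise, as the step of a 1.4-fold higher number from compound 1 to compound 4 (0.13 log units; within the scatter) indicates. Compound 4 is therefore estimated at 15 mg/kg, within a range of 5 mg/kg to 45 mg/kg.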

Compound 4, dose for half-maximal effect: 10 mg/kg
The estimate for compound 4 lay 1.5-fold (0.18 log units) above the measured number; the range from low to high includes it.
By their numbers in this assay, from the lowest: compounds 4 and 1 (each within the scatter of the next); then compounds 3 and 2 (each within the scatter of the next).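

On the saturated chain carbon bound to a carbonyl carbon, the ethoxycarbonyl group gives way to a group of 3 heavy atoms, 1 of them sulfur, and in this assay this exchange gives a 1.1-fold lower number from compound 1 to compound 4 (0.04 log units; within the scatter). The ethoxycarbonyl group is therefore not required at this place to keep the number at the level of compound 1. No measurement on hand explains why the two groups read alike.

As far as these compounds go, whether a carboxylic acid or an amine at this place would also read alike in this assay remains open. So does the effect of a longer chain.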